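Benzyloxy thiourea series: positional chlorine swap, second pairing

This account rests on a few compounds, and the source may have more. Where it says the series, first, only, none or still open, it means among the compounds named here.

Measured so far in a functional assay on SW-620 cells (Homo sapiens) for inhibition, read by MTT assay, with a stated time of 48 h; a higher number here means a weaker inhibitor, a lower number a stronger inhibitor:
compound 1 `Cc1ccc(NC(=S)NC(=O)c2ccc(OCc3ccc(Cl)c(Cl)c3)cc2)cc1-c1nc2ccccc2[nH]1` gives 30700 nM
compound 2 `Cc1ccc(NC(=S)NC(=O)c2ccc(OCc3ccc(Cl)cc3Cl)cc2)cc1-c1nc2ccccc2[nH]1` gives 57200 nM
compound 3 `O=C(NC(=S)Nc1ccc(Cl)c(-c2nc3ccccc3[nH]2)c1)c1ccc(OCc2ccc(Cl)c(Cl)c2)cc1` gives 24900 nM

Compound 4 `O=C(NC(=S)Nc1ccc(Cl)c(-c2nc3ccccc3[nH]2)c1)c1ccc(OCc2ccc(Cl)cc2Cl)cc1` is not yet measured in this assay.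

Compound 3 differs from compound 1 by chloro in place of methyl on an aromatic carbon; this shift in the core moves the number little, a 1.2-fold lower number from compound 1 to compound 3 (0.09 log units; within the scatter).

The change from compound 1 to compound 2 is 2,4-dichlorophenyl in place of 3,4-dichlorophenyl on a saturated chain carbon bound to an oxygen on an aromatic ring. The same change separates compound 3 from compound 4, (2,4-dichlorophenyl in place of 3,4-dichlorophenyl on a saturated chain carbon bound to an oxygen on an aromatic ring); both times the place is described in identical words, so it is the same change made on two cores that differ by the chloro-for-methyl exchange. Its measured step is a 1.9-fold higher number from compound 1 to compound 2 (0.27 log units; within the scatter).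

No other pairing of this swap is shown, so the expectation rests on a single step. Compound 4 is expected to sit somewhat weaker than compound 3, with a step estimated at a 1.8-fold higher number from compound 3 to compound 4 (0.26 log units; within the scatter), because the earlier swap gave a 1.9-fold higher number from compound 1 to compound 2 (0.27 log units; within the scatter) on a core of very similar potency. For compound 4 the estimated value in this assay is 45000 nM, with a likely range from 20000 nM to 100000 nM.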

Compound 4, half-maximal inhibitory concentration: 50200 nM
Compound 4: the middle estimate sits 1.1-fold (0.05 log units) below what was measured; low and high end bracket the measured number.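

In this assay, 2,4-dichlorophenyl in place of 3,4-dichlorophenyl gives a 2.0-fold higher number from compound 3 to compound 4 (0.30 log units; within the scatter), and the change carries from one core to the other without a measurable difference: the same change on two cores in this assay, a 1.9-fold higher number (0.27 log units; within the scatter) from compound 1 to compound 2 and a 2.0-fold higher number (0.30 log units; within the scatter) from compound 3 to compound 4, 1.1-fold (0.03 log units) apart, within the scatter of two such steps

The chloro-for-methyl exchange, read on the 2,4-dichlorophenyl compounds, gives a 1.1-fold lower number from compound 2 to compound 4 (0.06 log units; within the scatter), and it too matches its earlier step: the same change on two cores in this assay, a 1.2-fold lower number (0.09 log units; within the scatter) from compound 1 to compound 3 and a 1.1-fold lower number (0.06 log units; within the scatter) from compound 2 to compound 4, 1.1-fold (0.03 log units) apart, within the scatter of two such steps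

These four compounds fit simple additivity of the two changes on these two cores, but every step lies within the scatter, so the agreement is between small steps; it does not establish that either change has a real effect by itself, and it does not show that the match would hold on a third core.

Open, as far as these compounds go, is how the number responds when the dichlorophenyl ring gives way to an unsubstituted phenyl or the benzyl group to a longer alkyl chain. Equally open, from the compounds shown here alone, is what a methoxy group or an amine would do in the place held by the chloro or methyl on the core.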